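The source may hold more compounds than are shown below. What is called first, only, known or untested is meant among the compounds shown, and "the series" means these compounds.

Two members of the series carry numbers in an ADME assay on brain (Rattus norvegicus) for protein binding; a higher number here means a larger unbound share of the compound, a lower number a smaller unbound share. Compound 1 `Cc1c(CF)nnc2sc(C(=O)NC3CN(c4ncc(C(F)(F)F)cn4)C3)c(N)c12` gives 0.085 in this assay, the higher of the two. Compound 2 `COc1cc(N2CC(NC(=O)c3sc4nnc(Cl)c(C)c4c3N)C2)c(Cl)cn1` gives 0.01 in this assay, a smaller unbound share, and the gap between the two lies beyond the usual scatter; the two structures differ in more than one place, so no single change is tied to that gap. Compound 3 `Cc1c(Cl)nnc2sc(C(=O)NC3CN(c4ncc(C(F)(F)F)cn4)C3)c(N)c12` has not yet been measured. It differs from compound 1 by chloro in place of fluoromethyl on an aromatic carbon. Going by the values given here, no measured pair isolates this change. A modest decrease in unbound fraction is expected, a 1.4-fold lower number from compound 1 to compound 3 (0.15 log units; within the scatter), at the edge of the scatter, because compound 2, which also carries chloro and gives 0.01, points the same way even though it differs elsewhere. For compound 3 the expected value is 0.06, in the range 0.025 to 0.14.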

Compound 3, unbound fraction: 0.037
Compound 3: the middle estimate sits 1.6-fold (0.21 log units) above what was measured, and the stated range covers the measured number.
By their numbers in this assay, from the lowest: compound 2; then compound 3; then compound 1.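

In this assay, chloro in place of fluoromethyl on the aromatic carbon next to the ring nitrogen now has a direct reading: a 2.3-fold lower number from compound 1 to compound 3 (0.36 log units; beyond the scatter), with the rest of compound 1 unchanged. This shows that the unbound share responds to this position, which the earlier comparison could not show, as compound 1 and compound 2 differ in more than one place. Nothing available explains the step.

Going by these compounds alone, only two groups have been compared at this position, so it remains open how an amine, a nitrile or a longer chain such as ethyl would read there. Also open, on these data alone, is whether the same step holds when other parts of the compound differ, as this single pair cannot show that.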